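A few compounds are considered here, and "the series" means these few. Any claim that something is new, unique, unknown or untested is made for them only; others in the source may bear on it.

Compound 3 `CCOC(=O)[C@@H]1CCCN(S(=O)(=O)c2ccc(S(=O)(=O)N3CCNCC3)cc2)C1` carries a piperazin-1-yl group on one of its sulfonyl sulfurs. In a functional assay on BXPC-3 cells (Homo sapiens) for inhibition, read by MTT assay, with a stated time of 7 days (on this read-out lower numbers stand for stronger inhibition and higher numbers for weaker inhibition), compound 3 gives only a limit, > 30000 nM, so no exact number is known for it (the limit of > 30000 nM in this assay, at which 1 of the 3 values shown sits). Two close relatives frame it. Compound 1 `CCOC(=O)[C@@H]1CCCN(S(=O)(=O)c2ccc(S(=O)(=O)N3CCCCC3)cc2)C1`, with piperidin-1-yl at that position, gives 3300 nM in this assay. Compound 2 `CCOC(=O)[C@@H]1CCCN(S(=O)(=O)c2ccc(S(=N)(=O)N(CC)CC)cc2)C1`, carrying an open-chain group without a ring at the same position, gives 3600 nM in this assay. The steps to compound 3 are both sizeable: an at least 9.0-fold higher number from compound 1 to compound 3 (0.95 log units; beyond the scatter) and an at least 8.3-fold higher number from compound 2 to compound 3 (0.92 log units; beyond the scatter), each beyond the scatter.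

Compound 4 `CCCN(CC)S(=O)(=O)c1ccc(S(=O)(=O)N2CCC[C@@H](C(=O)OCC)C2)cc1` differs from compound 3 in one place: ethyl(propyl)amino in place of piperazin-1-yl on a sulfonyl sulfur. The entering group, like that of compound 2, has no ring and no hydrogen-bond donor, so the change largely undoes what separated compound 3 from compound 1 and compound 2. A step toward lower numbers is therefore expected, roughly an at least 8.5-fold lower number from compound 3 to compound 4 (0.93 log units; beyond the scatter) in this assay. Compound 4 is estimated at 3500 nM in this assay, with a likely range from 1500 nM to 9000 nM.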

Compound 4, half-maximal inhibitory concentration: 300 nM
The estimate for compound 4 lay 12-fold (1.07 log units) above the measured number, outside the stated range (below it).
By their numbers in this assay, from the lowest: compound 4; then compounds 1 and 2 (each within the scatter of the next). At a limit, above all of these: compound 3.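

In this assay, going by these compounds alone, ethyl(propyl)amino on the sulfonyl sulfur gives an 11-fold lower number from compound 1 to compound 4 (1.04 log units; beyond the scatter), so this position can do far more than the earlier compounds showed. Having no ring is not enough on its own, as compound 2 also carries an open-chain group, and the step there is a 12-fold lower number from compound 2 to compound 4 (1.08 log units; beyond the scatter). The step away from piperazin-1-yl is an at least 100-fold lower number from compound 3 to compound 4 (2.00 log units; beyond the scatter), but compound 3 gives only a limit, so the true size of that step is unknown: the limit of > 30000 nM in this assay, at which 1 of the 4 values shown sits.

Within the data shown here, only one open-chain group on a sulfonyl sulfur appears here, so it remains unclear how much depends on the exact ethyl and propyl chains. Groups such as dipropylamino or dibutylamino at this position would show whether shorter or longer chains give similar numbers.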